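Amide-Linked Aryl Ring in Place of the Anilide Urea Arm

The source may hold more compounds than are shown below. What is called first, only, known or untested is meant among the compounds shown, and "the series" means these compounds.

Compound 1 `COc1cc(-c2nn(-c3cccc(NC(=O)Nc4ccc(Cl)c(Cl)c4)c3)cc2-c2ccncc2)ccc1Cl` holds the lower of the two measured numbers: in a functional assay on HOP-62 cells (Homo sapiens) for inhibition, read by sulforhodamine B assay, with a stated time of 48 h (a lower number here means a stronger inhibitor of growth, a higher number a weaker inhibitor of growth), compound 1 gives 4900 nM, while compound 2 `O=C(Nc1cccc(-n2cc(-c3ccncc3)c(-c3ccc(Cl)c(O)c3)n2)c1)Nc1ccc(Cl)c(Cl)c1` gives 17600 nM. Going by the values given here, the only measured step, a 3.6-fold higher number from compound 1 to compound 2 (0.56 log units; beyond the scatter), concerns a change elsewhere on the shared core, hydrogen in place of methyl on an oxygen on an aromatic ring. Compound 3 `COc1cc(-c2nn(-c3cccc(NC(=O)c4ccc(Cl)c(C(F)(F)F)c4)c3)cc2-c2ccncc2)ccc1Cl` differs from compound 1 by 4-chloro-3-(trifluoromethyl)phenyl in place of (3,4-dichlorophenyl)amino on a carbonyl carbon, on a carbonyl carbon whose other neighbour is an amide-type nitrogen. Among the compounds with values here, no measured step touches this part of the molecule, so the size and direction of the step in this assay cannot be read from the two measured compounds. The expectation is therefore a step of about a 1.2-fold higher number from compound 1 to compound 3 (0.09 log units; within the scatter), with a wide range around it. Compound 3 is estimated at 6000 nM, expected to fall between 1500 nM and 24000 nM.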

Compound 3, concentration for total growth inhibition: > 32500 nM
Compound 3 ended at the assay's limit (the forecaster's own chance of this, stated with the estimate: 5%); middle value at least 5.4-fold (0.73 log units) from the limit.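

At the carbonyl carbon whose other neighbour is an amide-type nitrogen, the arm clearly matters in this assay: 4-chloro-3-(trifluoromethyl)phenyl in place of (3,4-dichlorophenyl)amino gives an at least 6.6-fold higher number from compound 1 to compound 3 (0.82 log units; beyond the scatter). The value of compound 3 is a limit of the assay, not a number, so this step has a floor but no measured size: the limit of > 32500 nM in this assay, at which 1 of the 3 values shown sits. This one change removes the amino nitrogen with its hydrogen-bond donor and also brings in trifluoromethyl, so the two cannot be told apart.

Still open, as far as these compounds go, is whether the amino nitrogen or the ring substitution carries the step, which a urea arm bearing 4-chloro-3-(trifluoromethyl)phenyl could separate. Also open, from the compounds shown here alone, is how a carboxylic acid or an amine on that aryl ring would read in this assay.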